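The source may report more compounds than this note shows. Statements on the series, on what has been measured and on what is new or still open speak of the compounds shown alone.

Measured in an ADME assay on Raji cells (Homo sapiens) for cytotoxicity, with a stated time of 72 h; on this read-out higher numbers stand for an effect only at larger amounts of compound and lower numbers for an effect already at smaller amounts:
compound 1 `Cc1cc(NC(=O)Nc2ccccc2N)c2ccccc2n1`: > 25000 nM
compound 2 `Cc1ccc(NC(=O)Nc2cc(C)nc3ccccc23)cc1`: > 25000 nM
compound 3 `Cc1cc(NC(=O)Nc2cccc(F)c2)c2ccccc2n1`: > 25000 nM

Compound 1 gives > 25000 nM, which is a limit of the assay and not a number. The other two entries are limits as well, so compound 1 has no readable rank within this small set, and the whole series sits together in the limit of > 25000 nM in this assay, at which 3 of the 3 values shown sit.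

The next compound is compound 4 `Cc1cc(NC(=O)Nc2ccccc2C(N)=O)c2ccccc2n1`, which keeps the core of compound 1 and changes one group: carbamoyl in place of amino on an aromatic carbon. In words, carbamoyl in place of amino on an aromatic carbon, ortho to a large group.

Among the compounds with values here, three measured steps bear on this change, all of them exchanges of the aryl group on the amide-type nitrogen: a step that the two limits leave unreadable from compound 1 to compound 2, a step that the two limits leave unreadable from compound 1 to compound 3 and a step that the two limits leave unreadable from compound 2 to compound 3. None of them has a readable size. In the first two, the 2-aminophenyl group is lost without any value emerging from the limit.

No step beyond the scatter is therefore expected in this assay, and no direction can be assigned. This expectation rests on compound 1, whose > 25000 nM is only a limit. The estimated step is a step that the limit leaves unreadable from compound 1 to compound 4. For compound 4 the expected value is 30000 nM, with an estimated range of 15000 nM to 60000 nM.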

Compound 4, half-maximal effective concentration: > 25000 nM
Compound 4 was reported as a limit (the forecaster's own chance of this, stated with the estimate: 85%); the middle value is on the limit's open side.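

In this assay compound 4 gives > 25000 nM as a limit of the assay and not a number. Compound 1 also stands at a limit, so no step can be read between compound 1 and compound 4, and the series stays together: the limit of > 25000 nM in this assay, at which 4 of the 4 values shown sit.

The compounds shown leave open whether any change on the shared core gives a readable value in this assay.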